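A few compounds are considered here, and "the series" means these few. Any claim that something is new, unique, unknown or untested is made for them only; others in the source may bear on it.

In a functional assay on HL-60 cells (Homo sapiens) for antiproliferative activity, read by MTT assay (on this read-out higher numbers stand for weaker inhibition and lower numbers for stronger inhibition), the measured compounds stand as follows

compound 1 `O[C@@H]1[C@@H](OCc2ccccc2)[C@H](OCc2ccccc2)[C@@H](COCc2ccccc2)O[C@@H]1CC1CCCCC1` gives 17200 nM
compound 2 `O[C@@H]1[C@@H](OCc2ccccc2)[C@H](OCc2ccccc2)[C@@H](COCc2ccccc2)O[C@@H]1Cc1ccccc1` gives "not active" (no number reported)
compound 3 `CCCC[C@H]1O[C@H](COCc2ccccc2)[C@@H](OCc2ccccc2)[C@H](OCc2ccccc2)[C@H]1O` gives "not active" (no number reported)

Among the measured compounds shown here, only one of these three compounds has a number, since compound 1 reaches 17200 nM on this scale. Compound 2 shares its standing with compound 3, which is reported as "not active" (no number reported) and so has no single value to start from. Any step away from compound 3 therefore begins without a fixed point.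

Compound 4 `CC(C)(C)C[C@H]1O[C@H](COCc2ccccc2)[C@@H](OCc2ccccc2)[C@H](OCc2ccccc2)[C@H]1O` has not yet been measured. The structural change is tert-butyl in place of propyl on a saturated chain carbon bound to a saturated ring carbon and, cut one bond further out, it reads butyl to neopentyl. The rest of the molecule stays the same.

For the measured compounds named here, no measured pair in this small set shows a change of this kind, so the expectation is only a rough one. In this assay no large step is expected. Any change would have to run towards stronger inhibition, since compound 3 has no measurable activity to lose. Compound 4 is expected to stay weak, either not active or in the region where compound 1 sits with 17200 nM on the scale. If a number is reported, the estimate for compound 4 is 30000 nM as a middle value, with an expected range from 12000 nM to 80000 nM in this assay.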

Compound 4, half-maximal inhibitory concentration: 12100 nM
Beside the measured number, compound 4's estimate is 2.5-fold (0.39 log units) above it; the range from low to high includes it.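

In this assay compound 3 gives "not active" (no number reported) while compound 4 gives 12100 nM as a measurable value, so replacing propyl with tert-butyl on a saturated chain carbon bound to a saturated ring carbon, which turns butyl into neopentyl, separates a compound with no reported number from one with a number. Compared with cyclohexyl, tert-butyl gives a 1.4-fold lower number from compound 1 to compound 4 (0.15 log units; within the scatter) and so cannot be told apart from it in this assay even though it has no ring. Compound 4 therefore shows that a ring is not required for a number in this assay, while compound 2, whose phenyl group does contain a ring, is also reported without one, so the presence of a ring alone does not sort these compounds. Nothing available explains why these groups give different outcomes.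

The compounds shown leave open whether a longer branched chain would give a lower number than either compound 1 or compound 4. They also leave open how a group carrying an amine or a carboxylic acid would behave in this same place, since every group compared here contains only carbon and hydrogen.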